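Replacing a Ring Hydrogen with a Hydroxyethoxy Group

The source may report more compounds than this note shows. Statements on the series, on what has been measured and on what is new or still open speak of the compounds shown alone.

Compound 1, `CCCN(CCC)c1cnc(-c2c(C)cc(C)cc2OC)nc1C`: 561 nM in an in vitro assay on IMR-32 cells for displacement of a labelled ligand from corticotropin-releasing factor receptor 1 (Homo sapiens); a higher number here means a weaker inhibitor, a lower number a stronger inhibitor
Compound 2, `CCCN(CCC)c1c(C)nc(-c2c(C)cc(C)cc2OC)nc1OC`: 15 nM
Compound 3, `CCCN(CCC)c1c(C)nc(-c2c(C)cc(C)cc2OC)nc1OC(C)C`: > 5000 nM, which is a limit of this assay and not a number.

Of the two numbers shown, compound 1 gives the highest; its nearest neighbour is compound 2, reached by a 37-fold lower number from compound 1 to compound 2 (1.57 log units; beyond the scatter). Compound 4, `CCCN(CCC)c1c(C)nc(-c2c(C)cc(C)cc2OC)nc1OCCO`, differs from compound 1 by 2-hydroxyethoxy in place of hydrogen on an aromatic carbon. Going by the values given here, two measured steps bear on this change: a 37-fold lower number from compound 1 to compound 2 (1.57 log units; beyond the scatter) and an at least 8.9-fold higher number from compound 1 to compound 3 (0.95 log units; beyond the scatter), while an at least 330-fold higher number from compound 2 to compound 3 (2.52 log units; beyond the scatter) shows how strongly the outcome at this position depends on what sits on the oxygen. The 2-hydroxyethoxy group is neither of the two groups already tested, so an outcome between them is expected. Compound 4 is therefore estimated at 200 nM, within 30 nM to 1500 nM. The expected step is a 2.8-fold lower number from compound 1 to compound 4 (0.45 log units; beyond the scatter).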

Compound 4, inhibition constant: 1610 nM
Compound 4: the middle estimate sits 8.1-fold (0.91 log units) below what was measured; the whole stated range lies below it.
By their numbers in this assay, from the lowest: compound 2; then compound 1; then compound 4. At a limit, above all of these: compound 3.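

In this assay, a group on oxygen at this position does not guarantee a gain over hydrogen, since 2-hydroxyethoxy gives a 2.9-fold higher number from compound 1 to compound 4 (0.46 log units; beyond the scatter). Extending methoxy by one hydroxymethyl gives a 110-fold higher number from compound 2 to compound 4 (2.03 log units; beyond the scatter), whereas 2-hydroxyethyl in place of isopropyl gives an at least 3.1-fold lower number from compound 3 to compound 4 (0.49 log units; beyond the scatter). The > 5000 nM of compound 3 is a limit of the assay and not a number.

Ethoxy, which carries the added carbon without the hydroxyl, remains open. So does 2-aminoethoxy, which has an amine where compound 4 has its hydroxyl.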